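From bromo to methylsulfanyl on a shared core

This account rests on a few compounds, and the source may have more. Where it says the series, first, only, none or still open, it means among the compounds named here.

- compound 1 `FC(F)(F)c1nccc(N[C@H]2CC[C@@H](Nc3ccc4nncn4n3)CC2)n1`: 1.7
- compound 2 `FC(F)(F)c1nccc(N[C@H]2CC[C@@H](Nc3ccc4nnc(Br)n4n3)CC2)n1`: 2.9

In a physicochemical assay for lipophilicity, read by LC-MS (on this read-out lower numbers stand for lower lipophilicity and higher numbers for higher lipophilicity), compound 2 stands highest of the two, at 2.9. Compound 3 `CSc1nnc2ccc(N[C@H]3CC[C@@H](Nc4ccnc(C(F)(F)F)n4)CC3)nn12` differs from it in one place: methylsulfanyl in place of bromo on an aromatic carbon. Going by the values given here, only one measured step bears on this, a large one, a number 1.20 log units higher from compound 1 to compound 2 (beyond the scatter), with bromo in place of hydrogen. No measurement compares bromo and methylsulfanyl directly. Since compound 3 also carries a group rather than hydrogen there, most of that rise should remain. The expected change is small and downward, a number 0.30 log units lower from compound 2 to compound 3 (within the scatter). Compound 3 is estimated at 2.6, within 2.2 to 3.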

Compound 3, distribution coefficient: 2.8
For compound 3 the middle estimate is 0.20 log units below the measured one; measured number inside the range.
By their numbers in this assay, from the lowest: compound 1; then compounds 3 and 2 (each within the scatter of the next).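

In this assay, methylsulfanyl and bromo read alike at this position on the shared core (a number 0.10 log units lower from compound 2 to compound 3 (within the scatter)). Methylsulfanyl in place of hydrogen also gives a large step (a number 1.10 log units higher from compound 1 to compound 3 (beyond the scatter)), so the large rise seen with bromo is not confined to that one group. Nothing available here explains either step. Still open, from the compounds shown here alone, is how an amine or a carboxylic acid at this position would read in this assay. Going by these compounds, a longer chain on the sulfur is equally open.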